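The source may hold more compounds than are shown below. What is called first, only, known or untested is meant among the compounds shown, and "the series" means these compounds.

In a functional assay on MDA-MB-231 cells (Homo sapiens) for cytotoxicity, read by MTT assay, with a stated time of 72 h (a lower number here means a stronger inhibitor, a higher number a weaker inhibitor), compound 1 (`O=C1c2c[n+]([O-])c3ccccc3c2C(=O)c2c1c1ccccc1n2Cc1cn([C@@H]2C[C@H](O)[C@@H](CO)O2)nn1`) gives 130 nM and compound 2 (`CN1CCN(CCCCn2c3c(c4ccccc42)C(=O)c2c[n+]([O-])c4ccccc4c2C3=O)CC1`) gives 110 nM, two values within the scatter of each other. Compound 3 (`O=C1c2c[n+]([O-])c3ccccc3c2C(=O)c2c1c1ccccc1n2CCCCN1CCNCC1`) gives 3310 nM, a higher number beyond the scatter from both. Compound 4 (`CC1(C)O[C@@H](CO)[C@H](Cn2cc(Cn3c4c(c5ccccc53)C(=O)c3c[n+]([O-])c5ccccc5c3C4=O)nn2)O1`) departs from compound 1 in a single place: (5-(hydroxymethyl)-2,2-dimethyl-1,3-dioxolan-4-yl)methyl in place of 4-hydroxy-5-(hydroxymethyl)oxolan-2-yl on an aromatic nitrogen. There, (5-(hydroxymethyl)-2,2-dimethyl-1,3-dioxolan-4-yl)methyl stands in place of 4-hydroxy-5-(hydroxymethyl)oxolan-2-yl on an aromatic nitrogen of a five-membered aromatic ring with 3 nitrogen. Among the compounds with values here, only one measured step exists, a 30-fold higher number from compound 2 to compound 3 (1.48 log units; beyond the scatter), and it is large, but it concerns hydrogen in place of methyl on an amine nitrogen in a ring. Within the data shown here, it therefore gives no direct measure of this exchange and shows only that one small change can matter in this set. With so little evidence, only a modest move toward a higher number is expected. The estimated step is a 1.5-fold higher number from compound 1 to compound 4 (0.19 log units; within the scatter), which would not lie beyond the scatter. Compound 4 is expected to give about 200 nM, with an estimated range from 60 nM to 700 nM.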

Compound 4, half-maximal inhibitory concentration: 680 nM
The estimate for compound 4 lay 3.4-fold (0.53 log units) below the measured number, within the range that was stated.
By their numbers in this assay, from the lowest: compounds 2 and 1 (each within the scatter of the next); then compound 4; then compound 3.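

In this assay, within the data shown here, the exchange on the aromatic nitrogen of the five-membered aromatic ring with 3 nitrogen gives the first measured step at this position, a 5.2-fold higher number from compound 1 to compound 4 (0.72 log units; beyond the scatter), which shows that the group held there can move the number beyond the scatter. The exchange alters the ring's hetero atoms, the heavy atoms, the hydrogen-bond donors and the defined stereocentres together, so the step cannot be assigned to any one of these differences. Nothing measured here accounts for the step.

The compounds shown leave open which part of the entering group matters, since no compound separates the two methyl groups from the rest of it. They also leave open whether an open-chain diol, a primary amine or a carboxylic acid on this nitrogen would stay close to compound 1 at 130 nM.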